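The source may report more compounds than this note shows. Statements on the series, on what has been measured and on what is new or still open speak of the compounds shown alone.

The series shares one core, seen in compound 1 `O=C1NC(=O)C2(CSC3=C2C(=O)c2ncccc2C3=O)N1`, compound 2 `Cc1ccc(N2NC(=O)NC3(CSC4=C3C(=O)c3ncccc3C4=O)C2=O)cc1` and compound 3 `CC(C)(C)c1ccc(N2C(=O)NC3(CSC4=C3C(=O)c3ncccc3C4=O)C2=O)cc1`. In a functional assay on XF498 cells (Homo sapiens) for antiproliferative activity, read by MTT assay, with a stated time of 96 h (on this read-out higher numbers stand for weaker inhibition and lower numbers for stronger inhibition), compound 1 gives 3120 nM, compound 2 gives 3800 nM and compound 3 gives 850 nM. Compound 2 thus carries the highest of the three numbers; its gap to compound 1 lies within the scatter, while compound 3 stands beyond it, at a lower number. Among the compounds with values here, the only single-place step measured so far, a 3.7-fold lower number from compound 1 to compound 3 (0.56 log units; beyond the scatter), concerns a group entering on an amide-type nitrogen in a ring, a different place from the change now in question. Compound 4 `O=C1NN(c2ccccc2)C(=O)C2(CSC3=C2C(=O)c2ncccc2C3=O)N1` differs from compound 2 by hydrogen in place of methyl on an aromatic carbon, which simply removes the methyl from the aryl group. Within the data shown here, no measured step tests such a change, and the removal is small, so the expected step of a 1.1-fold higher number from compound 2 to compound 4 (0.02 log units; within the scatter) is estimated to fall within the scatter, with no clear direction. Compound 4 is accordingly estimated at 4000 nM, with a range from 1800 nM to 9000 nM.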

Compound 4, half-maximal inhibitory concentration: 4550 nM
Compound 4: the middle estimate sits 1.1-fold (0.06 log units) below what was measured, within the range that was stated.
By their numbers in this assay, from the lowest: compound 3; then compounds 1, 2 and 4 (each within the scatter of the next).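

In this assay, the change from 4-methylphenyl to phenyl (a 1.2-fold higher number from compound 2 to compound 4 (0.08 log units; within the scatter)) lies within the scatter, so on this aromatic carbon, para to a large group, hydrogen and methyl cannot be told apart. Within the data shown here, this is the first measured step at this place, since the earlier step concerned a group entering on an amide-type nitrogen in a ring, and it shows that removing this single methyl leaves the number within the scatter. Nothing available bears on why compound 2 and compound 4 read alike. On these data alone, the pair compares only hydrogen and methyl, so what a chlorine atom, a methoxy group, an amine or a carboxylic acid on this carbon would do remains open. As far as these compounds go, whether a longer chain here would give a step beyond the scatter also remains open.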